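Fluoro to chloro swap on the sulfonamide aryl ring

The source may hold more compounds than are shown below. What is called first, only, known or untested is meant among the compounds shown, and "the series" means these compounds.

Compound 1 `O=C(/C=C/c1ccc2c(c1)OCCO2)NS(=O)(=O)c1ccc(F)cc1` and compound 2 `O=C(/C=C/c1ccc2c(c1)OCCO2)NS(=O)(=O)c1ccc(Cl)cc1` share one core and differ by chloro in place of fluoro on an aromatic carbon. In a functional assay on MCF7 cells (Homo sapiens) for antiproliferative activity, read by MTT assay, with a stated time of 48 h (a lower number here means a stronger inhibitor, a higher number a weaker inhibitor), compound 1 gives 52.1 ug/mL. In this assay compound 2 gives 51.3 ug/mL, which is a 1.0-fold lower number from compound 1 to compound 2 (0.01 log units; within the scatter). Compound 3 `O=C(/C=C/c1ccc2c(c1)OCCCO2)NS(=O)(=O)c1ccc(F)cc1` is built on a different core; the difference between the two cores is not broken down here. In this assay, among the compounds with values here, compound 3 gives > 100 ug/mL, which is a limit of the assay and not a number, and it is the one value that sits at the limit of > 100 ug/mL in this assay, at which 1 of the 3 values shown sits. Compound 4 `O=C(/C=C/c1ccc2c(c1)OCCCO2)NS(=O)(=O)c1ccc(Cl)cc1` has not been measured; it differs from compound 3 by chloro in place of fluoro on an aromatic carbon, the same change as that from compound 1 to compound 2, made at the same place on the other core. Because a 1.0-fold lower number from compound 1 to compound 2 (0.01 log units; within the scatter), the same change is expected to move the number for compound 4 little away from compound 3. Compound 4 is therefore estimated at 130 ug/mL, with an expected range from 60 ug/mL to 300 ug/mL. The step this estimate means is a step that the limit leaves unreadable from compound 3 to compound 4, and a result reported only as a limit is expected to be the more likely outcome.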

Compound 4, half-maximal inhibitory concentration: > 100 ug/mL
Compound 4 gave a limit, no number; the forecaster's own chance of this, stated with the estimate: 65%; the middle value is on the limit's open side.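

In this assay compound 4 gives > 100 ug/mL, a limit and not a number. Compound 3 gives > 100 ug/mL, also a limit, so no step can be read from compound 3 to compound 4: the limit of > 100 ug/mL in this assay, at which 2 of the 4 values shown sit.

The compounds shown leave open what numbers compound 3 and compound 4 would have, and so whether 4-fluorophenyl to 4-chlorophenyl matters on this core.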